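A few compounds are considered here, and "the series" means these few. Any claim that something is new, unique, unknown or untested is made for them only; others in the source may bear on it.

Compound 3 `COc1cc2c(Oc3ccc(NC(=O)c4nccc(-c5ccccc5)n4)cc3F)ccnc2cc1OCCCN1CCCCC1` gives 330 nM in a functional assay on NCI-H460 cells (Homo sapiens) for cytotoxicity, read by MTT assay, with a stated time of 72 h (on this read-out lower numbers stand for stronger inhibition and higher numbers for weaker inhibition), the highest of the three numbers shown. Compound 1 `COc1cc2c(Oc3ccc(NC(=O)c4cc(-c5ccccc5F)ccn4)cc3F)ccnc2cc1OCCCN1CCN(C)CC1` gives 140 nM in this assay, and compound 2 `COc1cc2c(Oc3ccc(NC(=O)c4cc(-c5ccccc5)ccn4)cc3F)ccnc2cc1OCCCN1CCCCC1` gives 120 nM. For the measured compounds named here, the only single-point step, a 2.8-fold higher number from compound 2 to compound 3 (0.44 log units; beyond the scatter), concerns the ring that carries the carbonyl, not the pendant phenyl. Compound 4 `COc1cc2c(Oc3ccc(NC(=O)c4nccc(-c5ccc(F)cc5F)n4)cc3F)ccnc2cc1OCCCN1CCCCC1` arises from compound 3 by 2,4-difluorophenyl in place of phenyl on an aromatic carbon. Going by the values given here, no measured pair isolates this change; compounds 1 and 2 differ at the pendant phenyl but also elsewhere, and their values sit within the scatter of each other. In this assay the change is therefore expected to give no change at the digits printed from compound 3 to compound 4 (within the scatter), nothing beyond the scatter. Compound 4 is estimated at 330 nM, within 150 nM to 700 nM.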

Compound 4, half-maximal inhibitory concentration: 550 nM
Compound 4: the middle estimate sits 1.7-fold (0.22 log units) below what was measured, and the stated range covers the measured number.
By their numbers in this assay, from the lowest: compounds 2 and 1 (each within the scatter of the next); then compounds 3 and 4 (each within the scatter of the next).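

In this assay, the first single-point read at the pendant aryl is a 1.7-fold higher number from compound 3 to compound 4 (0.22 log units; within the scatter). On the six-membered aromatic ring with 2 nitrogen, next to the ring nitrogen, 2,4-difluorophenyl in place of phenyl therefore gives no shift beyond the scatter. Nothing measured here speaks to the origin of this result.

As far as these compounds go, whether a methoxy, nitrile or amine on the phenyl would move the number beyond the scatter remains open. So does the outcome of the same exchange on the carbonyl-bearing ring of compound 2.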